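Adding one methoxy group to compound 1

The source may hold more compounds than are shown below. What is called first, only, known or untested is meant among the compounds shown, and "the series" means these compounds.

- compound 1 `COc1cc(N/C=C\C(=O)c2cn(-c3ccccc3)nc2-c2ccccc2)cc(OC)c1OC` gives 2350 nM as its value
- compound 2 `O=C(/C=C\Nc1ccc(C(F)(F)F)cc1)c1cn(-c2ccccc2)nc1-c1ccc(F)cc1` gives > 50000 nM as a limit

Among the measured compounds shown here, compound 1 gives 2350 nM in a functional assay on U-87MG ATCC cells (Homo sapiens) for antiproliferative activity, read by MTT assay, with a stated time of 48 h (a higher number here means a weaker inhibitor, a lower number a stronger inhibitor), and so holds the only actual number so far. For compound 2 the reading > 50000 nM is a limit, not a number. Compound 3 `COc1ccc(-c2nn(-c3ccccc3)cc2C(=O)/C=C\Nc2cc(OC)c(OC)c(OC)c2)cc1` keeps the core of compound 1 and carries one change, methoxy in place of hydrogen on an aromatic carbon described as phenyl to 4-methoxyphenyl. For the measured compounds named here, no measured pair shows this change, so in this assay the expected 1.1-fold lower number from compound 1 to compound 3 (0.03 log units; within the scatter) is small and has no firm direction. For compound 3 the estimate is 2200 nM with an expected range from 600 nM to 9000 nM for the coming measurement.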

Compound 3, half-maximal inhibitory concentration: > 50000 nM
Compound 3 ended at the assay's limit; the forecaster's own chance of this, stated with the estimate: 7%; at least 22-fold (1.35 log units) between middle value and limit.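

On the phenyl ring of compound 1, at the place para to a large group, the change to 4-methoxyphenyl is far from neutral: in this assay there is an at least 21-fold higher number from compound 1 to compound 3 (1.32 log units; beyond the scatter). The reading for compound 3 is a limit and not a number, so this step gives only the smallest possible size of the loss. Activity in these cells therefore depends on what sits at this position, at least for methoxy.

As far as these compounds go, it remains open whether only methoxy costs activity here. A hydroxyl group or a chlorine atom at the same place would help to show whether other groups are tolerated.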